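Removing the hydroxymethyl from the thioether chain of compound 2

This account rests on a few compounds, and the source may have more. Where it says the series, first, only, none or still open, it means among the compounds named here.

Among the compounds with values here, compound 2 `OCC#CCSc1cnc2ccccc2c1[Se]CC#CCBr` gives 0.2 ug/mL in a functional assay on CCRF-CEM cells (Homo sapiens) for cytotoxicity, read by sulforhodamine B assay, with a stated time of 72 h (on this read-out higher numbers stand for weaker inhibition and lower numbers for stronger inhibition), the lowest of the three numbers so far; compound 3 `C[Se]c1c(SCC#CCO)cnc2ccccc12` gives 2.1 ug/mL and compound 1 `OCC#CCSc1cnc2ccccc2c1Cl` gives 4.1 ug/mL. Compound 4 `C#CCSc1cnc2ccccc2c1[Se]CC#CCBr` differs from compound 2 by hydrogen in place of hydroxymethyl on a triple-bonded carbon. Within the data shown here, no measured step touches this part of the molecule: the two large steps, a 21-fold lower number from compound 1 to compound 2 (1.31 log units; beyond the scatter) and an 11-fold higher number from compound 2 to compound 3 (1.02 log units; beyond the scatter), both concern the group that replaced the chlorine atom of compound 1, while the hydroxymethyl-bearing chain is unchanged in all three measured compounds. Among the measured compounds shown here, with no precedent, the change is expected to give no step beyond the scatter in this assay. Compound 4 is therefore estimated at 0.3 ug/mL, with a range of 0.1 ug/mL to 1 ug/mL. The expected step is a 1.5-fold higher number from compound 2 to compound 4 (0.18 log units; within the scatter).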

Compound 4, concentration for 50% inhibition: 0.3 ug/mL
Estimate against measurement, compound 4: no gap at the digits printed, and the stated range covers the measured number.
By their numbers in this assay, from the lowest: compounds 2 and 4 (each within the scatter of the next); then compounds 3 and 1 (each within the scatter of the next).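

In this assay, within the data shown here, hydrogen in place of hydroxymethyl on a triple-bonded carbon gives a 1.5-fold higher number from compound 2 to compound 4 (0.18 log units; within the scatter), the only reading at this position. For this pair, 4-hydroxybut-2-yn-1-yl can be exchanged for propargyl without a step beyond the scatter, so the hydroxymethyl is not needed for the low number of compound 2. Nothing available explains this tolerance. On these data alone, whether an amine, a carboxylic acid or a longer chain on that carbon would be tolerated stays open. So does whether the same exchange holds with the groups of compound 1 or compound 3 in place of the bromine-bearing group.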